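The compounds below may be only part of what the source reports. "The series", "measured", "known", "first", "only" and "open" are said of these compounds alone.

Measured so far in a functional assay on U-937 cells (Homo sapiens) for inhibition, read by MTT assay, with a stated time of 24 h; on this read-out lower numbers stand for stronger inhibition of growth and higher numbers for weaker inhibition of growth:
- compound 1 `O=C1CC(c2cccc(NC(=O)c3ccc(Cl)c(C(F)(F)F)c3)c2)=Nc2cnn(Cc3ccccc3)c2N1`: 60 nM
- compound 2 `O=C1CC(c2ccc(NC(=O)c3ccc(Cl)c(C(F)(F)F)c3)cc2)=Nc2cnn(Cc3ccccc3)c2N1`: 60 nM
- compound 3 `Cc1cn(-c2cc(NC(=O)Nc3ccc(C4=Nc5cnn(Cc6ccccc6)c5NC(=O)C4)cc3)cc(C(F)(F)F)c2)cn1`: > 30000 nM

Compound 2 gives 60 nM and compound 1 gives 60 nM, the same value at the digits shown and so within the scatter. Compound 3 gives > 30000 nM, which is a limit and not a number.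

The account now turns to compound 4 `O=C1CC(c2ccc(NC(=O)Nc3cccc(Cl)c3)cc2)=Nc2cnn(Cc3ccccc3)c2N1`, which has not yet been measured in this assay. It differs from compound 2 in one place: (3-chlorophenyl)amino stands in place of 4-chloro-3-(trifluoromethyl)phenyl on a carbonyl carbon ((3-chlorophenyl)amino in place of 4-chloro-3-(trifluoromethyl)phenyl on a carbonyl carbon).

Among the compounds with values here, compound 3 is the only measured compound that also has an amino group on such a carbonyl carbon, and it differs from compound 4 in other ways too. For compound 3 the limit of > 30000 nM therefore points towards weaker inhibition of growth, but it is thin ground for judging the size of the change. A loss beyond the scatter is expected, with a higher number and a wide margin of doubt, and the estimated step is a 13-fold higher number from compound 2 to compound 4 (1.12 log units; beyond the scatter).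

For compound 4 the estimated value is 800 nM, with an expected range of 80 nM to 10000 nM.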

Compound 4, concentration for 50% growth inhibition: 670 nM
Compound 4: middle estimate off by 1.2-fold (0.08 log units), on the high side; the range from low to high includes it.
By their numbers in this assay, from the lowest: compounds 1 and 2 (each within the scatter of the next); then compound 4. At a limit, above all of these: compound 3.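

In this assay, within the data shown here, putting (3-chlorophenyl)amino in place of 4-chloro-3-(trifluoromethyl)phenyl on a carbonyl carbon gives the first change at this place that can be read as a number: an 11-fold higher number from compound 2 to compound 4 (1.05 log units; beyond the scatter). The step is large, so this place does not tolerate every group it is given, which compound 1 and compound 2 could not show, as both carry the same 4-chloro-3-(trifluoromethyl)phenyl group there. Compound 3 also has an amino group on such a carbonyl carbon, but it differs from compound 4 in other ways too, and its result is a limit and not a number: the limit of > 30000 nM in this assay, at which 1 of the 4 values shown sits.

The step changes several things at once, as the amino nitrogen enters while the trifluoromethyl group leaves and the chlorine changes its place on the ring, so the compounds shown cannot divide the loss among these parts. Still open, going by these compounds, is how a (4-chloro-3-(trifluoromethyl)phenyl)amino group on the carbonyl carbon would read, since it would keep the aromatic substituents of compound 2 and alter only the amino nitrogen.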